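Chain extension of the amine side chain in compound 2

A few compounds are considered here, and "the series" means these few. Any claim that something is new, unique, unknown or untested is made for them only; others in the source may bear on it.

Working notes on the series. Compound 2 `CNCCNc1cc2c(cc1F)c(=O)c(C(=O)O)cn2Cc1ccc(-c2ccccc2)cc1` is the reference point. In an assay on isolated protein for inhibition of DNA topoisomerase 1 (Homo sapiens), with a stated time of 15 min (on this read-out lower numbers stand for stronger inhibition and higher numbers for weaker inhibition), compound 2 gives > 200000 nM, which is a limit of the assay and not a number. Compound 1 `CNC[C@@H]1CCN(c2cc3c(cc2F)c(=O)c(C(=O)O)cn3Cc2ccc(-n3cccn3)cc2)C1` carries the amine within a ring; in this assay compound 1 gives > 200000 nM, again a limit. Compound 3 `CNCCNc1c(F)cc2c(=O)c(C(=O)O)cn(Cc3ccc(-c4ccccc4)cc3)c2c1OC` carries a methoxy in place of hydrogen on an aromatic carbon relative to compound 2; in this assay compound 3 gives > 200000 nM, also a limit. For the measured compounds named here, the one counted step, a step that the two limits leave unreadable from compound 2 to compound 3, cannot be sized, and the limit of > 200000 nM in this assay, at which 3 of the 3 values shown sit, shows that every value in the set sits at that same limit, so compound 2 stands level with both neighbours as far as the numbers reach.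

Compound 4 `CNCCCCNc1cc2c(cc1F)c(=O)c(C(=O)O)cn2Cc1ccc(-c2ccccc2)cc1` differs from compound 2 in one place: 2-(methylamino)ethyl in place of methylamino on a saturated chain carbon, two bonds along the chain from a nitrogen on an aromatic ring. Going by the values given here, no measured step bears on this change: a step that the two limits leave unreadable from compound 2 to compound 3 is unreadable, and the chain-length difference has no counterpart among the measured pairs. Nothing in the data points to a step in either direction beyond the scatter, and the likeliest outcome is that compound 4 also returns only a limit. The step that the limit leaves unreadable from compound 2 to compound 4 is accordingly expected to be negligible. Compound 4 is estimated at 300000 nM, with a range from 100000 nM to 1000000 nM.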

Compound 4, half-maximal inhibitory concentration: 88300 nM
Compound 4: middle estimate off by 3.4-fold (0.53 log units), on the high side, and the stated range ends above it.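

For the compounds shown here, the chain carried by the aromatic amine nitrogen is the first place where a change gives a readable result: in this assay, 2-(methylamino)ethyl in place of methylamino on a saturated chain carbon, two bonds along the chain from a nitrogen on an aromatic ring, gives an at least 2.2-fold lower number from compound 2 to compound 4 (0.35 log units; beyond the scatter). Going by these compounds alone, the earlier compounds could not show this, since the step for the methoxy change cannot be read, and compound 4 is the only compound in the set with a measured number: the limit of > 200000 nM in this assay, at which 3 of the 4 values shown sit. With compound 2 at a limit, the true size of the step remains unknown, but the direction is clear: the longer chain goes with the lower number.

Going by these compounds, one lengthening gives no trend, so it remains open whether the number falls steadily with chain length, as a comparison of the 3-(methylamino)propyl chain and a still longer chain would show. Also open, on these data alone, is whether the methylamino group on the longer chain matters, or whether a primary amine or dimethylamino there would give a similar number.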